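A few compounds are considered here, and "the series" means these few. Any claim that something is new, unique, unknown or untested is made for them only; others in the source may bear on it.

Measured compounds:
Compound 1, `N#Cc1ccc(CN2c3ccccc3C(=O)N(Cc3ccccc3)S2(=O)=O)cc1`, gives 62000 nM in a functional assay on MRC5 cells (Homo sapiens); a higher number here means that more compound is tolerated, a lower number that less compound is tolerated.
Compound 2, `N#Cc1ccc(CN2c3ccccc3C(OCc3ccccc3)=NS2(=O)=O)cc1`, gives 62000 nM in this assay.

Compound 1 stands level with compound 2 at the digits reported; the two values lie within the usual scatter of each other, so no order between them can be read. Compound 3, `O=C1c2ccccc2N(Cc2ccccc2)S(=O)(=O)N1Cc1ccccc1`, has not yet been measured in this assay. It differs from compound 1 by hydrogen in place of cyano on an aromatic carbon, in words hydrogen in place of cyano on an aromatic carbon. Going by the values given here, no measured pair shows what this change does, so the expectation for compound 3 rests on compound 1 alone, and the expected step is none beyond the scatter, in either direction. Compound 3 is therefore expected to give about 62000 nM in this assay, within a range from 30000 nM to 120000 nM. The step this estimate implies is no change at the digits printed from compound 1 to compound 3 (within the scatter).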

Compound 3, half-maximal cytotoxic concentration: 66000 nM
The estimate for compound 3 lay 1.1-fold (0.03 log units) below the measured number, within the range that was stated.
By their numbers in this assay, from the lowest: compounds 1, 2 and 3 (each within the scatter of the next).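

Replacing cyano with hydrogen on the aromatic carbon, para to a large group, gives a 1.1-fold higher number from compound 1 to compound 3 (0.03 log units; within the scatter) in this assay for this swap of 4-cyanobenzyl to benzyl. Going by these compounds alone, this is the first direct reading at this position, since compounds 1 and 2 differ from each other in more than one place. The nitrile is therefore not required for the level of tolerance seen with compound 1, and nothing shown explains why the two compounds read alike.

Only cyano and hydrogen are shown at this position, so the effect of an amine or a carboxylic acid there remains open. No step shown so far lies beyond the scatter, so it is also unknown which structural change, at this position or elsewhere on the shared core, would move this number.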